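Swapping 4-iodophenyl for 2-methoxyphenyl on the shared core

The source may hold more compounds than are shown below. What is called first, only, known or untested is meant among the compounds shown, and "the series" means these compounds.

In a functional assay on HeLa cells (Homo sapiens) for inhibition, read by sulforhodamine B assay (a higher number here means a weaker inhibitor, a lower number a stronger inhibitor), compound 1 `O=C1C(Nc2ccc(I)cc2)=CC(=O)c2c1nc1n2[C@H]2OC[C@@H](O)[C@H]2OC1` gives 4010 nM, and compound 2 `Cc1ccc(NC2=CC(=O)c3c(nc4n3[C@H]3OC[C@@H](O)[C@H]3OC4)C2=O)cc1C` gives 4320 nM. These two numbers sit level with each other, so compound 1 shares the best-measured place in this small set with compound 2. For compound 3 `O=C1C=C(NC2CCCCC2)C(=O)c2c1nc1n2[C@H]2OC[C@@H](O)[C@H]2OC1` the assay reports only a limit, > 16000 nM, and not a number.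

Compound 4 `COc1ccccc1NC1=CC(=O)c2c(nc3n2[C@H]2OC[C@@H](O)[C@H]2OC3)C1=O` carries 2-methoxyphenyl in place of 4-iodophenyl on an amine nitrogen. For the measured compounds named here, one measured step bears on this change. It puts 3,4-dimethylphenyl in place of 4-iodophenyl on the same nitrogen, and a 1.1-fold higher number from compound 1 to compound 2 (0.03 log units; within the scatter) stays within the scatter. A single step is thin evidence, and the new group differs from both of those already measured. Even so, that step gives no reason to expect a large shift in this assay, so the expected result is a 1.1-fold higher number from compound 1 to compound 4 (0.05 log units; within the scatter), with no clear change beyond the scatter. For compound 4 the estimated value is 4500 nM, with an expected range of 1800 nM to 12000 nM.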

Compound 4, half-maximal inhibitory concentration: 7460 nM
The estimate for compound 4 lay 1.7-fold (0.22 log units) below the measured number; low and high end bracket the measured number.
By their numbers in this assay, from the lowest: compounds 1, 2 and 4 (each within the scatter of the next). At a limit, above all of these: compound 3.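

In this assay, a third substituted phenyl group on this amine nitrogen again produces no shift that stands clear of the usual variation: a 1.9-fold higher number from compound 1 to compound 4 (0.27 log units; within the scatter), and a 1.7-fold higher number from compound 2 to compound 4 (0.24 log units; within the scatter). The earlier compounds shown here compared only 4-iodophenyl with 3,4-dimethylphenyl, whereas 2-methoxyphenyl brings oxygen and a hydrogen-bond acceptor, and even this exchange stays within the scatter. Compound 3, with cyclohexyl on the same nitrogen, still gives only a limit and not a number: the limit of > 16000 nM in this assay, at which 1 of the 4 values shown sits.

On these data alone, it remains open whether a plain phenyl group, or a phenyl ring carrying a carboxylic acid or an amine, would stay level with compounds 1, 2 and 4. Also open, as far as these compounds go, is whether a pyridine ring on this nitrogen would move the number beyond the scatter in either direction.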